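The source may hold more compounds than are shown below. What is called first, only, known or untested is meant among the compounds shown, and "the series" means these compounds.

Working notes on the series. Compound 1 `CCOC(=O)/C(C#N)=C(/Nc1ccc(Br)cc1)N[C@@H](C)c1ccccc1` gives in a functional assay on A-431 cells (Homo sapiens) for antiproliferative activity, read by MTT assay, with a stated time of 72 h, tested at 5 uM (a lower number here means less inhibition, a higher number more inhibition at the concentration tested (going by the name of the read-out)), a value of 19.3%. Compound 2 `CCOC(=O)/C(C#N)=C(/Nc1ccc(C(F)(F)F)cc1)N[C@@H](C)c1ccccc1` gives in this assay a value of 39.9%. Compound 2 holds the higher of the two numbers; the nearest is compound 1, and the step of a number 20.6 percentage points higher from compound 1 to compound 2 (beyond the scatter) lies beyond the scatter. Compound 3 `CCOC(=O)/C(C#N)=C(/Nc1ccc([N+](=O)[O-])cc1)N[C@@H](C)c1ccccc1` is not yet measured and differs from compound 2 in one place: nitro in place of trifluoromethyl on an aromatic carbon. For the measured compounds named here, the only measured step bearing on this is a number 20.6 percentage points higher from compound 1 to compound 2 (beyond the scatter), which exchanged one group on the same aromatic carbon for another and moved the read-out by a modest amount; it shows the group on that carbon matters, but no nitro-bearing compound has been measured. A step in this assay of about that size in either direction is therefore expected, with no strong lean. Compound 3 is expected to give about 38%, within a range from 18% to 60%. The expected step is a number 1.9 percentage points lower from compound 2 to compound 3 (within the scatter).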

Compound 3, a percentage reported as inhibition, at one concentration (the size of the read-out at that concentration, not a potency): 18.1%
Compound 3: the middle estimate sits 19.9 percentage points above what was measured, and the stated range covers the measured number.
By their numbers in this assay, from the lowest: compounds 3 and 1 (each within the scatter of the next); then compound 2.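

In this assay, the new step, a number 21.8 percentage points lower from compound 2 to compound 3 (beyond the scatter), shows that the higher number at this position does not extend to every replacement for bromo: on this aromatic carbon, trifluoromethyl stands apart from nitro as well. The other new step, a number 1.2 percentage points lower from compound 1 to compound 3 (within the scatter), does not separate nitro from bromo, so among the three groups only trifluoromethyl in compound 2 lies beyond the scatter of the others. Nothing available accounts for why trifluoromethyl stands apart from the other two groups.

The compounds shown leave open whether a methoxy group, an amine or a carboxylic acid on this aromatic carbon would fall with trifluoromethyl or with bromo and nitro. As far as these compounds go, each number is also a read-out at one concentration, so the potency of all three compounds remains open.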